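A few compounds are considered here, and "the series" means these few. Any claim that something is new, unique, unknown or untested is made for them only; others in the source may bear on it.

In an assay for inhibition of protein disulfide-isomerase (Homo sapiens), with a stated time of 1 h (on this read-out higher numbers stand for weaker inhibition and lower numbers for stronger inhibition), compound 1 `Oc1c(C(Nc2ccccn2)c2ccccc2Cl)ccc2cccnc12` gives 500 nM. Among the compounds with values here, this is the only numerical value so far in this assay; the other entry is a limit rather than a number. Compound 2 `Cc1ccnc(NC(c2ccccc2C)c2ccc3cccnc3c2O)c1` is reported in this assay only as > 40000 nM, which is an assay limit and not a measured figure. Within the data shown here, the series thus offers the limit of > 40000 nM in this assay, at which 1 of the 2 values shown sits, alongside a single figure, and no step between two measured compounds that differ in one place.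

Compound 3 `Oc1c(C(Nc2ccccn2)c2ccc(Cl)cc2)ccc2cccnc12` has yet to be measured in this assay. It differs from compound 1 by 4-chlorophenyl in place of 2-chlorophenyl on a saturated chain carbon bound to an aromatic carbon and a nitrogen on an aromatic ring; that is, 4-chlorophenyl in place of 2-chlorophenyl on a saturated chain carbon bound to an aromatic carbon and a nitrogen on an aromatic ring. Among the measured compounds shown here, no measured pair shows what this exchange does here, so the size and direction of the step rest on the structures alone. A modest weakening is expected, with no firm basis for a swing far beyond the usual scatter. Compound 3 is expected to give about 1500 nM in this assay, within 300 nM to 8000 nM. The expected step is a 3.0-fold higher number from compound 1 to compound 3 (0.48 log units; beyond the scatter).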

Compound 3, half-maximal inhibitory concentration: 170 nM
Compound 3: middle estimate off by 8.8-fold (0.95 log units), on the high side; the whole stated range lies above it.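

In this assay, within the data shown here, 4-chlorophenyl in place of 2-chlorophenyl on a saturated chain carbon bound to an aromatic carbon and a nitrogen on an aromatic ring gives a 2.9-fold lower number from compound 1 to compound 3 (0.47 log units; beyond the scatter), the first step that can be read between compounds differing in one place. The leaving and entering groups have the same atoms and the same counts, so this place responds to how those atoms are joined and not only to which atoms are present, and of these two groups 4-chlorophenyl gives the lower number. No measured property among the data shown accounts for the size or direction of this step.

Open, going by these compounds, is whether phenyl without chlorine, 3-chlorophenyl or 4-methoxyphenyl on the same carbon would take the number in this assay further down or back up, and whether the step holds with other groups elsewhere on the molecule. Compound 2 differs from compound 1 in more than one place, so it does not separate the contribution of any single change. Compound 2 is recorded only as an assay limit, > 40000 nM.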